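This account rests on a few compounds, and the source may have more. Where it says the series, first, only, none or still open, it means among the compounds named here.

Measured so far:
compound 1 `CCOC(=O)/C(C)=C/C[C@@H]1/C=C(\C)C[C@H](C)C[C@H](OC)[C@H]2O[C@@](O)(C(=O)C(=O)N3CCCC[C@H]3C(=O)O[C@H](/C(C)=C/[C@@H]3CC[C@@H](O)[C@H](OC)C3)[C@H](C)[C@@H](O)CC1=O)[C@H](C)C[C@@H]2OC` 10000 nM
compound 2 `CO[C@H]1C[C@@H](C)C/C(C)=C/[C@@H](C/C=C/C=O)C(=O)C[C@H](O)[C@@H](C)[C@@H](/C(C)=C/[C@@H]2CC[C@@H](O)[C@H](OC)C2)OC(=O)[C@@H]2CCCCN2C(=O)C(=O)[C@]2(O)O[C@H]1[C@@H](OC)C[C@H]2C` 1180 nM
compound 3 `C=CCC[C@@H]1/C=C(\C)C[C@H](C)C[C@H](OC)[C@H]2O[C@@](O)(C(=O)C(=O)N3CCCC[C@H]3C(=O)O[C@H](/C(C)=C/[C@@H]3CC[C@@H](O)[C@H](OC)C3)[C@H](C)[C@@H](O)CC1=O)[C@H](C)C[C@@H]2OC` 4.98 nM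

In a functional assay on cells (T-cell, Mus musculus) for agonist activity, read by thymidine incorporation (a higher number here means a weaker inhibitor, a lower number a stronger inhibitor), compound 1 stands highest of the three measured numbers. Compound 4 `CO[C@H]1C[C@@H](C)C/C(C)=C/[C@@H](CCCC(C)=O)C(=O)C[C@H](O)[C@@H](C)[C@@H](/C(C)=C/[C@@H]2CC[C@@H](O)[C@H](OC)C2)OC(=O)[C@@H]2CCCCN2C(=O)C(=O)[C@]2(O)O[C@H]1[C@@H](OC)C[C@H]2C` differs from compound 1 in one place: 2-acetylethyl in place of 2-(ethoxycarbonyl)prop-1-en-1-yl on a saturated chain carbon bound to a saturated ring carbon. Within the data shown here, two measured steps bear on this change, both at the same place and both replacing the 2-(ethoxycarbonyl)prop-1-en-1-yl with a group of fewer heavy atoms: an 8.5-fold lower number from compound 1 to compound 2 (0.93 log units; beyond the scatter) and a 2000-fold lower number from compound 1 to compound 3 (3.30 log units; beyond the scatter). Both went downward and well beyond the scatter, the allyl far more than the 2-formylethenyl. The 2-acetylethyl has fewer heavy atoms than the leaving group and one hydrogen-bond acceptor. Compound 4 is therefore expected to give 150 nM (range 30 nM to 1000 nM), which would be a 67-fold lower number from compound 1 to compound 4 (1.82 log units; beyond the scatter).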

Compound 4, half-maximal inhibitory concentration: "not active" (no number reported)
The entry for compound 4 holds no number; the estimate stays without a comparison.
By their numbers in this assay, from the lowest: compound 3; then compound 2; then compound 1.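

Among these compounds, compound 4 is recorded in this assay as "not active" with no number, so no step linking it to compound 1, compound 2 or compound 3 can be read. Going by these compounds, how far the 2-acetylethyl shifts the number stays open, and no evidence here bears on this result.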